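This account rests on a few compounds, and the source may have more. Where it says the series, first, only, none or still open, it means among the compounds named here.

Compound 1 `CS(=O)(=O)Nc1ccc(-c2nc3ccccc3o2)cc1` carries a methyl on its sulfonyl sulfur. In an assay on cells for inhibition of HSP60/HSP10 (Homo sapiens), with a stated time of 60 min (on this read-out lower numbers stand for stronger inhibition and higher numbers for weaker inhibition), compound 1 reaches only the limit of the assay, > 100000 nM. Compound 2 `O=S(=O)(Nc1ccc(-c2nc3ccccc3o2)cc1)c1ccccc1F` has a 2-fluorophenyl in that place. In this assay compound 2 likewise stops at the limit, > 100000 nM. Compound 3 `O=S(=O)(Nc1ccc(-c2nc3ccccc3o2)cc1)c1ccccc1O` carries a 2-hydroxyphenyl on the sulfonyl sulfur. In this assay compound 3 also gives only the limit, > 100000 nM. Where compound 3 stands is therefore known only as a limit, and the same holds for the other two, all sitting at the limit of > 100000 nM in this assay, at which 3 of the 3 values shown sit. The steps between them are accordingly unreadable: a step that the two limits leave unreadable from compound 1 to compound 2, a step that the two limits leave unreadable from compound 1 to compound 3 and a step that the two limits leave unreadable from compound 2 to compound 3.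

Compound 4 `C=Cc1ccc(S(=O)(=O)Nc2ccc(-c3nc4ccccc4o3)cc2)cc1` differs from compound 3 in one place: 4-vinylphenyl in place of 2-hydroxyphenyl on a sulfonyl sulfur. The measured steps that bear on this change are those that swap the group on the sulfonyl sulfur, and none of them yields a readable size, so no direction beyond the scatter can be expected. Compound 4 is therefore expected to stay at or near the limit, with an estimate of 100000 nM and a range from 30000 nM to 300000 nM. The step this estimate implies, a number no higher from compound 3 to compound 4 (the limit leaves the size open), is an expectation and not a measurement.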

Compound 4, half-maximal inhibitory concentration: > 100000 nM
Compound 4 gave a limit, no number; the forecaster's own chance of this, stated with the estimate: 80%; the middle value sits exactly at the limit.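

In this assay compound 4 also gives only a limit, not a number (> 100000 nM). Its steps from compound 1, compound 2 and compound 3 cannot be read. The compounds shown leave open whether any of these groups on the sulfonyl sulfur differs from another in inhibition.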